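Trimming the Ester on a Shared Core

A few compounds are considered here, and "the series" means these few. Any claim that something is new, unique, unknown or untested is made for them only; others in the source may bear on it.

Compound 2 `CCOC(=O)[C@@H]1C[C@@]23CN(C)C[C@@H](CCC4=C2[C@H]1CC4=O)C31CC[C@](CC)(OC)OC1` is tested in a functional assay on HL-60 cells (Homo sapiens) for cytotoxicity, read by MTT assay, with a stated time of 48 h (on this read-out lower numbers stand for stronger inhibition and higher numbers for weaker inhibition), and in that test compound 2 shows only a limit of the assay, > 40000 nM. Its close relative compound 1 `CCOC(=O)[C@@H]1C[C@@]23CN(C)C[C@@H](CCC4=C2[C@@H]1CC4=O)C31CC[C@](CC)(OC)OC1` likewise gives a limit in this assay, > 40000 nM. Among the compounds with values here, the only measured step, a step that the two limits leave unreadable from compound 1 to compound 2, cannot be read because of the limit of > 40000 nM in this assay, at which 2 of the 2 values shown sit. Compound 3 `CC[C@]1(OC)CCC2(CO1)[C@@H]1CCC3=C4[C@@H](CC3=O)[C@H](C(=O)OC)C[C@@]42CN(C)C1` differs from compound 2 by hydrogen in place of methyl on a saturated chain carbon bound to an oxygen next to a carbonyl group. Within the data shown here, no measured step covers this change, so the numbers give no size or direction for it. Compound 3 is therefore expected to stay at the limit, estimated at 60000 nM with a range from 20000 nM to 200000 nM. The step that the limit leaves unreadable from compound 2 to compound 3 is thus expected to lie within scatter.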

Compound 3, half-maximal inhibitory concentration: > 40000 nM
Compound 3: a limit, no number; the forecaster's own chance of this, stated with the estimate: 85%; the middle value does not contradict the limit.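

No step can be read among compound 1, compound 2 and compound 3, because all three stop at a limit: the limit of > 40000 nM in this assay, at which 3 of the 3 values shown sit. As far as these compounds go, whether swapping ethoxycarbonyl for methoxycarbonyl or changing the stereocentre alters activity in this assay stays open.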